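Lengthening the Hydroxycarbamoyl Chain Beyond Compound 2

The source may hold more compounds than are shown below. What is called first, only, known or untested is meant among the compounds shown, and "the series" means these compounds.

Among the compounds with values here, in a functional assay on HepG2 cells (Homo sapiens) for inhibition, read by MTT assay, with a stated time of 72 h (a higher number here means a weaker inhibitor, a lower number a stronger inhibitor), compound 2, `Nc1nc2cc(-c3nn(CCCCC(=O)NO)c4ncnc(N)c34)ccc2o1`, gives 2100 nM, the only actual number so far. Compound 1, `Nc1nc2cc(-c3nn(CCCC(=O)NO)c4ncnc(N)c34)ccc2o1`, gives > 50000 nM in this assay, and this is a limit of the assay, not a number. Within the data shown here, the single measured step, an at least 23-fold lower number from compound 1 to compound 2 (1.37 log units; beyond the scatter), is large and also extends the chain. Compound 3, `Nc1nc2cc(-c3nn(CCCCCCCCC(=O)NO)c4ncnc(N)c34)ccc2o1`, takes the extension further: 4-(hydroxycarbamoyl)butyl in place of hydroxycarbamoyl on a saturated chain carbon, four bonds along the chain from an aromatic nitrogen. In words, 4-(hydroxycarbamoyl)butyl stands in place of hydroxycarbamoyl on a saturated chain carbon, four bonds along the chain from an aromatic nitrogen. With only an at least 23-fold lower number from compound 1 to compound 2 (1.37 log units; beyond the scatter) to go on, a further fall in this assay is expected, though a more moderate one, and the estimate stays wide. The expected change is a 3.0-fold lower number from compound 2 to compound 3 (0.48 log units; beyond the scatter). For compound 3 the estimated value is 700 nM, with an expected range of 120 nM to 4000 nM.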

Compound 3, half-maximal inhibitory concentration: 2610 nM
The estimate for compound 3 lay 3.7-fold (0.57 log units) below the measured number, within the range that was stated.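

In this assay, within the data shown here, the further extension gives a 1.2-fold higher number from compound 2 to compound 3 (0.09 log units; within the scatter), so the values of the two chains cannot be told apart, and the single earlier step does not continue as a steady fall with chain length. Compound 3 is the compound that goes against such a trend, since 4-(hydroxycarbamoyl)butyl in place of hydroxycarbamoyl brings no gain that can be read at this position. The shortest chain still stands apart, with an at least 19-fold lower number from compound 1 to compound 3 (1.28 log units; beyond the scatter), but the size of that step is open-ended, as compound 1 gives a limit of the assay and not a number: the limit of > 50000 nM in this assay, at which 1 of the 3 values shown sits.

On these data alone, it remains open whether a chain of intermediate length would differ from both compound 2 and compound 3. Also open, as far as these compounds go, is how a still longer chain, or a carboxylic acid in place of the hydroxycarbamoyl end, would read in this assay.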